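The source may report more compounds than this note shows. Statements on the series, on what has been measured and on what is new or still open speak of the compounds shown alone.

Measured in a functional assay on brain (Rattus norvegicus, strain Wistar) for inhibition; a higher number here means a weaker inhibitor, a lower number a stronger inhibitor:
- Compound 1 `CCCCCCCc1ccc(-c2c(C)[nH]c(=O)n2C2CCCCC2)cc1`: 8700 nM
- Compound 2 `CCCCCCCCc1ccc(-c2c(C)[nH]c(=O)n2C2CCCCC2)cc1`: 10300 nM
- Compound 3 `CCCCCCCCCCc1ccc(-c2c(C)[nH]c(=O)n2C2CCCCC2)cc1`: 27000 nM

Compound 3 has the highest number of the three and so is the weakest inhibitor among them. The next compound, compound 4 `CCCCCCCCCCCCCCCCCCc1ccc(-c2c(C)[nH]c(=O)n2C2CCCCC2)cc1`, carries a much longer chain, and its difference from compound 3 is octyl in place of hydrogen on a saturated chain carbon, ten or more bonds along the chain from an aromatic carbon.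

Among the compounds with values here, three measured steps bear on this change. The shortest extension gave a 1.2-fold higher number from compound 1 to compound 2 (0.07 log units; within the scatter), which shows no clear change. The larger extensions gave a 2.6-fold higher number from compound 2 to compound 3 (0.42 log units; beyond the scatter) and a 3.1-fold higher number from compound 1 to compound 3 (0.49 log units; beyond the scatter), both modest. The added octyl is longer than any of these extensions, so the measured steps must be stretched well past their range, and the data cannot show whether the rise continues evenly. Starting from compound 3 at 27000 nM, a further rise in the number is expected, meaning a weaker inhibitor, and the step is likely to be modest to moderate.

The expected change is a 2.2-fold higher number from compound 3 to compound 4 (0.35 log units; beyond the scatter).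

For compound 4 the estimated value is 60000 nM, with an expected range from 18000 nM to 200000 nM.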

Compound 4, half-maximal inhibitory concentration: > 100000 nM
Compound 4: a limit, no number; the forecaster's own chance of this, stated with the estimate: 30%; middle value at least 1.6-fold (0.22 log units) away from the limit.
By their numbers in this assay, from the lowest: compounds 1 and 2 (each within the scatter of the next); then compound 3. At a limit, above all of these: compound 4.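

In this assay compound 4 gives no number, only a limit: the limit of > 100000 nM in this assay, at which 1 of the 4 values shown sits. Read against that limit, the octyl change gives an at least 3.7-fold higher number from compound 3 to compound 4 (0.56 log units; beyond the scatter), and the longer comparisons give an at least 9.7-fold higher number from compound 2 to compound 4 (0.98 log units; beyond the scatter) and an at least 11-fold higher number from compound 1 to compound 4 (1.06 log units; beyond the scatter), the last of these large. Within the data shown here, the earlier compounds showed only modest steps, so this result shows that the rise in the number carries on to the much longer chain and that the total change along the series reaches a large size, with compounds 1 and 2 the one pair that does not separate.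

On these data alone, how far compound 4 lies past its limit stays open, so the true size of these steps cannot be read, nor whether the rise is even along the chain. Also open, as far as these compounds go, is how an amine or a carboxylic acid in place of the octyl would read.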